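A Methyl Replacing Hydroxy on the Styryl Ring

The compounds below may be only part of what the source reports. "The series", "measured", "known", "first", "only" and "open" are said of these compounds alone.

Measured in a functional assay on MCF7 cells (Homo sapiens) for inhibition, read by sulforhodamine B assay, with a stated time of 72 h; on this read-out higher numbers stand for weaker inhibition and lower numbers for stronger inhibition:
Compound 1, `O=c1[nH]c2ccc(Br)cc2nc1/C=C/c1ccc(Br)cc1`: 0.0322 ug/mL
Compound 2, `O=c1[nH]c2ccc(Br)cc2nc1/C=C/c1ccc(O)cc1`: 0.0228 ug/mL

Compound 2 holds the lowest of the two numbers in this assay; its nearest neighbour is compound 1, and the step of a 1.4-fold lower number from compound 1 to compound 2 (0.15 log units; within the scatter) shows that the two values sit within the ordinary scatter, so neither compound can be called stronger than the other. Compound 3, `Cc1ccc(/C=C/c2nc3cc(Br)ccc3[nH]c2=O)cc1`, has not been measured. It differs from compound 2 by methyl in place of hydroxy on an aromatic carbon. Going by the values given here, only one measured step bears on this change: a 1.4-fold lower number from compound 1 to compound 2 (0.15 log units; within the scatter), in which a hydroxy replaced a bromo and left the two values within the scatter. Among the compounds with values here, no measured pair exchanges hydroxy for methyl, so the change itself is untested. Within the data shown here, since the one substituent swap in hand produced no step beyond the scatter, the step of a 1.3-fold higher number from compound 2 to compound 3 (0.12 log units; within the scatter) is expected to lie within the scatter as well. Compound 3 is therefore estimated at 0.03 ug/mL in this assay, with a range from 0.012 ug/mL to 0.08 ug/mL.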

Compound 3, half-maximal inhibitory concentration: 0.0222 ug/mL
Beside the measured number, compound 3's estimate is 1.4-fold (0.13 log units) above it; the range from low to high includes it.
By their numbers in this assay, from the lowest: compounds 3, 2 and 1 (each within the scatter of the next).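

In this assay the exchange of hydroxy for methyl can now be read directly (a 1.0-fold lower number from compound 2 to compound 3 (0.01 log units; within the scatter)), and so can the exchange of bromo for methyl (a 1.5-fold lower number from compound 1 to compound 3 (0.16 log units; within the scatter)). Removing the hydroxy also removes its hydrogen-bond donor and acceptor, yet the step stays within the scatter, so hydroxy, bromo and methyl cannot be told apart at this position in this assay. No supporting measurement is available to explain this closeness.

As far as these compounds go, whether a group of another kind at this position, such as an amine, a carboxylic acid or a longer chain like butyl, would also stay within the scatter remains open. The compounds shown also leave open whether the same holds when the core carries something other than its present bromo.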